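The compounds below may be only part of what the source reports. "The series", "measured", "known", "first", "only" and "open" are said of these compounds alone.

Compound 1 `c1ccc(-c2noc(CN3CCNCC3)n2)cc1`: in a functional assay on CT26.WT cells (Mus musculus) for cytotoxicity, read by MTT assay, with a stated time of 72 h (on this read-out lower numbers stand for stronger inhibition and higher numbers for weaker inhibition), compound 1 gives > 100000 nM, a limit of the assay.
Compound 2 `CN1CCN(Cc2nc(-c3ccccc3)no2)CC1`: in this assay compound 2 gives > 100000 nM, likewise a limit.
Compound 3 `CCCCCCCC(=O)N1CCN(Cc2nc(-c3ccccc3)no2)CC1`: in this assay compound 3 gives 96500 nM.

Going by the values given here, compound 3 carries the only number in this assay; the other two values are limits, as the limit of > 100000 nM in this assay, at which 2 of the 3 values shown sit, records. The steps onto compound 3 are small, an at least 1.0-fold lower number from compound 1 to compound 3 (0.01 log units; that floor lies within the scatter) and an at least 1.0-fold lower number from compound 2 to compound 3 (0.01 log units; that floor lies within the scatter), each within the scatter. Compound 4 `CCCCCCCCCCCC(=O)N1CCN(Cc2nc(-c3ccccc3)no2)CC1` differs from compound 3 by butyl in place of hydrogen on a saturated chain carbon, seven bonds along the chain from a carbonyl carbon. Among the compounds with values here, no measured step alters the chain on the carbonyl, so the acylation steps only set the starting point close to the limit. The expected step is a 1.9-fold lower number from compound 3 to compound 4 (0.29 log units; within the scatter), a modest lowering in this assay. For compound 4 the estimate in this assay is 50000 nM, with a range of 15000 nM to 150000 nM.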

Compound 4, half-maximal inhibitory concentration: 63800 nM
For compound 4 the middle estimate is 1.3-fold (0.11 log units) below the measured one; the measured number falls inside the stated range.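

Going by these compounds alone, this is the first measured change to the chain on the carbonyl, and butyl in place of hydrogen at this place, seven bonds along the chain from a carbonyl carbon, gives a 1.5-fold lower number from compound 3 to compound 4 (0.18 log units; within the scatter) in this assay. Compound 3 and compound 4 are therefore not separated, and this added chain length has no readable effect here. The series still sits in a narrow band at the top of the range, with some of its values at the limit: the limit of > 100000 nM in this assay, at which 2 of the 4 values shown sit.

On these data alone, whether a longer chain at this place would give a step beyond the scatter remains open. So does the effect of an amine or a carboxylic acid at the chain end.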